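A few compounds are considered here, and "the series" means these few. Any claim that something is new, unique, unknown or untested is made for them only; others in the source may bear on it.

Notes on the series

Compound 1 `N#Cc1ccc(NC(=O)c2cc(-c3ccccc3)ccc2O)cc1` is the reference for the first pair. In a functional assay on KG-1 cells (Homo sapiens) for cytotoxicity, read by luminescence and CellTiter-Glo, with a stated time of 3 days (on this read-out higher numbers stand for weaker inhibition and lower numbers for stronger inhibition), compound 1 gives 1300 nM. Compound 3 `N#Cc1ccc(NC(=O)c2cc(F)ccc2O)cc1` differs from it at one place: fluoro in place of phenyl on an aromatic carbon. The change produced a 2.1-fold higher number from compound 1 to compound 3 (0.31 log units; beyond the scatter).

Compound 2 `O=C(Nc1cc(C(F)(F)F)cc(C(F)(F)F)c1)c1cc(Br)c(-c2ccccc2)cc1O` carries a different core; how its core differs from that of compound 1 is not broken down here. In this assay, among the compounds with values here, compound 2 gives 300 nM, the lowest of the three numbers so far, and its steps to compound 1 and to compound 3 are both beyond the scatter. Compound 3 gives 2670 nM in this assay, the highest of the three.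

Compound 4 `O=C(Nc1cc(C(F)(F)F)cc(C(F)(F)F)c1)c1cc(Br)c(F)cc1O` is not yet measured. It differs from compound 2 by fluoro in place of phenyl on an aromatic carbon. Within the data shown here, this is the same kind of change as the one from compound 1 to compound 3, but the surroundings of the place are not identical: in compound 4 the fluoro stands ortho to a bromo group, meta to a hydroxy group and para to a large group, whereas in compound 3 it stands meta to a large group and para to a hydroxy group. Among the measured compounds shown here, the one measured instance gave a modest rise in the number, and a step of similar size is expected here, a 2.2-fold higher number from compound 2 to compound 4 (0.34 log units; beyond the scatter), because compound 2 starts from 300 nM and the earlier pair moved by a 2.1-fold higher number from compound 1 to compound 3 (0.31 log units; beyond the scatter). For the measured compounds named here, the expected value for compound 4 in this assay is therefore 650 nM, with a plausible range from 300 nM to 1500 nM, the range being wide since only one instance of the change is known and the place differs.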

Compound 4, half-maximal inhibitory concentration: 510 nM
For compound 4 the middle estimate is 1.3-fold (0.11 log units) above the measured one; measured number inside the range.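

In this assay, fluoro in place of phenyl on an aromatic carbon gives a 1.7-fold higher number from compound 2 to compound 4 (0.23 log units; within the scatter), so on the core of compound 2 the step alone cannot be told apart from the scatter of repeated measurements. Taken with the earlier pair on the core of compound 1, the two steps do not differ: the same change on two cores in this assay, a 2.1-fold higher number (0.31 log units; beyond the scatter) from compound 1 to compound 3 and a 1.7-fold higher number (0.23 log units; within the scatter) from compound 2 to compound 4, 1.2-fold (0.08 log units) apart, within the scatter of two such steps. This shows that, for these two cores, the change carries over without a detectable dependence on the core, but with only two instances it sets no rule for other cores, and it does not show that the agreement would hold at another place, since the fluoro in compound 4 stands ortho to a bromo group, meta to a hydroxy group and para to a large group, surroundings not shared with compound 3.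

The compounds shown leave open how an amine, a carboxylic acid or a longer alkyl chain would behave on that aromatic carbon, where only phenyl and fluoro appear here. Within the data shown here, also open is what the bromo group and the two trifluoromethyl groups each contribute, as compound 1 and compound 2 differ in more than one place and no single-place pair separates them.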